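Swapping the Aryl Group on the Carbonyl of Compound 3

This account rests on a few compounds, and the source may have more. Where it says the series, first, only, none or still open, it means among the compounds named here.

The compounds share a core carrying two fluorophenyl rings on a chain that ends at a carbonyl. For compound 1 `O=C(NCCCCC(c1ccc(F)cc1)c1ccc(F)cc1)Nc1ccc(I)cc1` the result in an ADME assay on isolated protein for inhibition of sodium-dependent dopamine transporter (Homo sapiens) (on this read-out lower numbers stand for stronger inhibition and higher numbers for weaker inhibition), is "not determined" (no result reported). Compound 2 `CC(=O)Nc1cc(NC(=O)NCCCCC(c2ccc(F)cc2)c2ccc(F)cc2)ccc1Cl` gives 609 nM in this assay. Among the measured compounds shown here, compound 3 `Cc1ccc(NC(=O)NCCCCC(c2ccc(F)cc2)c2ccc(F)cc2)cc1C` gives 80 nM in this assay, the lowest of the two numbers known. The step of a 7.6-fold lower number from compound 2 to compound 3 (0.88 log units; beyond the scatter) shows that exchanging the aryl group on the amide-type nitrogen shifts the read-out modestly.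

Compound 4 `O=C(NCCCCC(c1ccc(F)cc1)c1ccc(F)cc1)c1ccc(Cl)c(C(F)(F)F)c1` differs from compound 3 by 4-chloro-3-(trifluoromethyl)phenyl in place of (3,4-dimethylphenyl)amino on a carbonyl carbon. For the measured compounds named here, no measured pair shows an aryl ring placed directly on the carbonyl in place of an arylamino group, so the only guidance is the step of a 7.6-fold lower number from compound 2 to compound 3 (0.88 log units; beyond the scatter), which indicates that changes at this end of the molecule move the number modestly. The direction is uncertain, and a weakening is expected as the more likely outcome. For compound 4 the expected value in this assay is 200 nM, with a range from 40 nM to 1000 nM, which corresponds to an expected step of a 2.5-fold higher number from compound 3 to compound 4 (0.40 log units; beyond the scatter).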

Compound 4, inhibition constant: 603 nM
Estimate against measurement, compound 4: 3.0-fold (0.48 log units) below; the range from low to high includes it.
By their numbers in this assay, from the lowest: compound 3; then compounds 4 and 2 (each within the scatter of the next).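

In this assay, the change at the carbonyl carbon gives a 7.5-fold higher number from compound 3 to compound 4 (0.88 log units; beyond the scatter), so this position does not tolerate the exchange without a clear loss. The earlier compounds shown here varied only the aryl group on a nitrogen that stayed in place, whereas here the amino nitrogen and its hydrogen-bond donor leave along with the dimethylphenyl ring, and a 4-chloro-3-(trifluoromethyl)phenyl ring sits directly on the carbonyl carbon. No measurement shown accounts for this step.

Going by these compounds, compound 4 changes the linking nitrogen and the ring substituents at once, so it remains open which of the two matters, and a 4-chloro-3-(trifluoromethyl)phenyl ring kept on the nitrogen would separate them. Also open, on these data alone, is how a carboxylic acid or an amine on the ring, or a longer chain before the carbonyl, would read out.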